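Nitro to Cyano at a Low Level of Growth Inhibition

The compounds below may be only part of what the source reports. "The series", "measured", "known", "first", "only" and "open" are said of these compounds alone.

Compound 1 `CCOC(=O)c1ccc(Nc2ccnc(SCC(=O)c3ccc([N+](=O)[O-])cc3)n2)cc1` was tested in a functional assay on M14 cells (Homo sapiens) for inhibition, read by sulforhodamine B assay, with a stated time of 48 h, tested at 10 uM (a lower number here means less inhibition of growth, a higher number more inhibition of growth at the concentration tested), where compound 1 gives 16%. Of the two numbers recorded, that of compound 1 is the highest, yet compound 2 `COc1ccc(C(=O)CSc2nccc(Nc3cccc(C(C)=O)c3)n2)cc1`, which in this assay gives 15%, lies within the scatter of it, so the two cannot be told apart. Among the measured compounds shown here, no pair of measured compounds differing in a single place exists here, so no measured step is available to guide the next change.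

Compound 3 `CCOC(=O)c1ccc(Nc2ccnc(SCC(=O)c3ccc(C#N)cc3)n2)cc1` has not yet been measured. It differs from compound 1 in one place: cyano in place of nitro on an aromatic carbon The nitro leaves and the cyano enters on an aromatic carbon of a six-membered aromatic ring of carbon only, para to a large group; cut one bond further out, 4-nitrophenyl becomes 4-cyanophenyl.

Both compound 1 at 16% and compound 2 at 15% sit low in this assay. The step is expected to be small, in no set direction, and not beyond the scatter: a number 2 percentage points lower from compound 1 to compound 3 (within the scatter). Compound 3 is therefore estimated at 14%, within a range from 2% to 30% in this assay.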

Compound 3, percent growth inhibition at one concentration: 49%
The estimate for compound 3 lay 35 percentage points below the measured number, outside the stated range (above it).
By their numbers in this assay, from the lowest: compounds 2 and 1 (each within the scatter of the next); then compound 3.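

In this assay, among the compounds shown here, the exchange of nitro for cyano on an aromatic carbon of a six-membered aromatic ring of carbon only, para to a large group, gives a number 33 percentage points higher from compound 1 to compound 3 (beyond the scatter) and is the first measured step in this set. For the compounds shown here, it shows that this position is not silent: one change there, with the rest of compound 1 kept, moves the number clear of the low level that the earlier compounds shared, something their two values could not show, as they differ in more than one place. No measurement at hand bears on why the number moves with this exchange, so the step stands as an observation only.

Going by these compounds, it remains open whether the higher number belongs to cyano in particular, or whether another group on the same carbon, such as a chlorine atom, a primary amide or a carboxylic acid, would give a similar one. On these data alone, it is also open whether the same exchange would give a step of like size with the ethyl ester on the other side of the molecule replaced by a different group.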